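A few compounds are considered here, and "the series" means these few. Any claim that something is new, unique, unknown or untested is made for them only; others in the source may bear on it.

Working notes on the series, read in a functional assay on HepG2 cells (Homo sapiens) for antiproliferative activity, read by CCK-8 assay, with a stated time of 72 h; a higher number here means a weaker inhibitor, a lower number a stronger inhibitor. Compound 1 `Nc1ccccc1NC(=O)c1ccc(COc2ccc([N+](=O)[O-])cc2)cc1` gives > 32000 nM, which is a limit and not a number. Compound 2 `Nc1ccccc1NC(=O)c1ccc(COc2ccc(Br)cc2)cc1` gives > 32000 nM, again only a limit. Among the compounds with values here, compound 3 `CCc1ccc(OCc2ccc(C(=O)Nc3ccccc3N)cc2)cc1` gives 6960 nM, the only true number so far and the strongest of the three.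

Next comes compound 4 `COc1ccc(OCc2ccc(C(=O)Nc3ccccc3N)cc2)cc1`: methoxy in place of ethyl on an aromatic carbon, para to a large group. Within the data shown here, no measured step involves methoxy. The nearest evidence is an at least 4.5-fold lower number from compound 1 to compound 3 (0.66 log units; beyond the scatter) and an at least 4.5-fold lower number from compound 2 to compound 3 (0.66 log units; beyond the scatter), both beyond the scatter, while a step that the two limits leave unreadable from compound 1 to compound 2 stays unreadable. Those two steps show that losing ethyl from compound 3 at 6960 nM can cost much in this assay, so a higher number is the likelier direction. The expected change is a 1.6-fold higher number from compound 3 to compound 4 (0.20 log units; within the scatter), a modest weakening. For compound 4 the estimated value is 11000 nM, with an expected range of 3500 nM to 32000 nM.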

Compound 4, half-maximal inhibitory concentration: 4200 nM
Compound 4: middle estimate off by 2.6-fold (0.42 log units), on the high side, and the stated range covers the measured number.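

At this position, para to a large group, methoxy and ethyl cannot be told apart: a 1.7-fold lower number from compound 3 to compound 4 (0.22 log units; within the scatter). Methoxy therefore sits with ethyl and not with bromo or nitro: an at least 7.6-fold lower number from compound 2 to compound 4 (0.88 log units; beyond the scatter), and an at least 7.6-fold lower number from compound 1 to compound 4 (0.88 log units; beyond the scatter). Those last two steps each start from a limit, not a number: the limit of > 32000 nM in this assay, at which 2 of the 4 values shown sit.

Going by these compounds, it remains open whether an amine, a hydroxyl or a longer chain such as ethoxy at this place would stay level with compound 3 and compound 4. On these data alone, the true distance of compound 1 and compound 2 from them also remains open.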